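The source may report more compounds than this note shows. Statements on the series, on what has been measured and on what is new or still open speak of the compounds shown alone.

Compound 1: `CN(Cc1ccc(C(=O)O)cc1)c1ccc(OCc2c(-c3c(Cl)cccc3Cl)noc2C2CC2)nc1C(F)(F)F` — 30 nM
Compound 2: `CN(Cc1ccc(C(=O)NCCS(=O)(=O)O)cc1)c1ccc(OCc2c(-c3c(Cl)cccc3Cl)noc2C2CC2)nc1C(F)(F)F` — 1420 nM
Compound 3: `CCN(Cc1ccc(C(=O)O)cc1)c1ccc(OCc2c(-c3c(Cl)cccc3Cl)noc2C2CC2)nc1C(F)(F)F` — 180 nM

In a functional assay on HEK293 cells for agonist activity at Bile acid receptor (Homo sapiens) (a higher number here means that more compound is needed for the effect, a lower number that less compound is needed), compound 1 gives the lowest of the three numbers, with compound 3 nearest and compound 2 furthest. The unmeasured compound 4, `O=C(O)c1ccccc1OCc1ccc(OCc2c(-c3c(Cl)cccc3Cl)noc2C2CC2)nc1C(F)(F)F`, differs from compound 1 in one place: (2-carboxyphenoxy)methyl in place of (4-carboxybenzyl)(methyl)amino on an aromatic carbon. Among the compounds with values here, two measured steps bear on it. Replacing the carboxylic acid of compound 1 with a (2-sulfoethyl)amide cost a 47-fold higher number from compound 1 to compound 2 (1.68 log units; beyond the scatter), while a methyl in place of a hydrogen on the chain carbon of compound 1 cost a 6.0-fold higher number from compound 1 to compound 3 (0.78 log units; beyond the scatter). Compound 4 keeps an acid but reworks the whole linking group, a larger change than either step, so a loss in this assay is expected, of roughly a 10-fold higher number from compound 1 to compound 4 (1.00 log units; beyond the scatter). Compound 4 is therefore estimated at 300 nM, within 60 nM to 3000 nM.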

Compound 4, half-maximal effective concentration: 1710 nM
Beside the measured number, compound 4's estimate is 5.7-fold (0.76 log units) below it; the range from low to high includes it.
By their numbers in this assay, from the lowest: compound 1; then compound 3; then compounds 2 and 4 (each within the scatter of the next).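

In this assay, putting (2-carboxyphenoxy)methyl in place of (4-carboxybenzyl)(methyl)amino gives a 57-fold higher number from compound 1 to compound 4 (1.76 log units; beyond the scatter) even though a carboxylic acid is kept. Keeping an acid in this group is therefore not enough at this position, ortho to a trifluoromethyl group; the rest of the group matters as well. No measurement shown here explains the loss.

This single change alters both the link to the core and where the acid sits on the ring, so the compounds shown leave open which alteration matters. A (2-carboxybenzyl)(methyl)amino group would keep the original link while carrying the acid as in compound 4.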